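The source may hold more compounds than are shown below. What is called first, only, known or untested is meant among the compounds shown, and "the series" means these compounds.

Compound 1 (`c1ccc(Sc2nn3cc(-c4cc5ccccc5o4)nc3s2)cc1`) offers no number to start from: in an ADME assay on microsomes from liver (Rattus norvegicus) for metabolic stability, with a stated time of 10 min (a higher number here means that more of the compound is left, a lower number that less of the compound is left), compound 1 stands as "not determined" (no result reported) and so sets no baseline. For the measured compounds named here, two relatives are the only guide. Compound 2 (`COc1cc(OCc2ccccc2OCc2ccccc2)c2cc(-c3cn4nc(OC)sc4n3)oc2c1`) shows 22% of the compound left and compound 3 (`COc1nn2cc(-c3cc4c(OC)ccc(OC)c4o3)nc2s1`) shows 28% left, a pair within the usual scatter of each other. The move to compound 4 (`CCOc1nn2cc(-c3cc4ccccc4o3)nc2s1`) is a single swap on the shared core (ethoxy in place of phenylsulfanyl on an aromatic carbon) in which ethoxy takes the place of phenylsulfanyl on an aromatic carbon. Going by the values given here, with no measured step to lean on, the expectation in this assay is no shift beyond the scatter away from compound 2 and compound 3 and no firm direction. Compound 4 is estimated at 28% with an expected range from 10% to 50% of the compound left.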

Compound 4, percent of the compound remaining: 37%
The estimate for compound 4 lay 9 percentage points below the measured number; low and high end bracket the measured number.
By their numbers in this assay, from the lowest: compounds 2, 3 and 4 (each within the scatter of the next, the first and the last beyond it).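

Compound 4 gives 37% in this assay while compound 1 stands as "not determined" (no result reported), so no step can be read between them. What ethoxy in place of phenylsulfanyl does here stays open, and nothing shown explains the value of compound 4.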